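Swapping a para fluorine for acetyl on the pendant phenyl

The source may report more compounds than this note shows. Statements on the series, on what has been measured and on what is new or still open speak of the compounds shown alone.

Measured so far in a functional assay on NCI/ADR-RES cells (Homo sapiens) for inhibition, read by sulforhodamine B assay, with a stated time of 48 h, tested at 10 uM; on this read-out higher numbers stand for more inhibition at the one concentration tested (going by the name of the read-out) and lower numbers for less inhibition:
compound 1 `Brc1cn2ccnc2c(-c2ccc3ncn(C4CCCCC4)c3c2)n1` gives 8.82%
compound 2 `COc1ccc(-c2cn3ccnc3c(-c3ccc4ncn(C5CCCCC5)c4c3)n2)cc1` gives 87.2%
compound 3 `Fc1ccc(-c2cn3ccnc3c(-c3ccc4ncn(C5CCCCC5)c4c3)n2)cc1` gives 0.69%

Compound 3 holds the lowest of the three numbers. Its nearest neighbour is compound 1, and the gap between them is within the scatter; compound 2 stands far above both, beyond the scatter.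

Compound 4 `CC(=O)c1ccc(-c2cn3ccnc3c(-c3ccc4ncn(C5CCCCC5)c4c3)n2)cc1` has not been measured. It differs from compound 3 in one place: acetyl in place of fluoro on an aromatic carbon

One measured step speaks most directly to this change, the replacement of a group at the same position on the same six-membered ring: a number 86.5 percentage points lower from compound 2 to compound 3 (beyond the scatter). It shows that what sits at that position can swing this assay from near nothing to strong inhibition. The step of a number 78.4 percentage points higher from compound 1 to compound 2 (beyond the scatter) likewise shows that the 4-methoxyphenyl arm carries the high reading. Nothing measured tells how acetyl compares with methoxy or fluoro there, so the direction is open; the expected step of a number 24.3 percentage points higher from compound 3 to compound 4 (beyond the scatter) is therefore hedged toward a modest rise with a wide spread. Compound 4 is estimated at 25%, within a range from 0% to 75%.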

Compound 4, a percentage reported as inhibition, at one concentration (the size of the read-out at that concentration, not a potency): 4.17%
For compound 4 the middle estimate is 20.8 percentage points above the measured one; measured number inside the range.
By their numbers in this assay, from the lowest: compounds 3, 4 and 1 (each within the scatter of the next); then compound 2.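

Acetyl now joins fluoro among the groups that leave this reading low in this assay: the step of a number 3.5 percentage points higher from compound 3 to compound 4 (within the scatter) is small, and the step of a number 4.7 percentage points lower from compound 1 to compound 4 (within the scatter) shows that the 4-acetylphenyl arm does no more than the bromo it replaces. A phenyl ring carrying a group at this place is therefore not enough for strong inhibition, and the step of a number 83 percentage points lower from compound 2 to compound 4 (beyond the scatter) leaves methoxy as the only group shown here that gives a high reading. Nothing available explains why methoxy stands apart from fluoro and acetyl.

Going by these compounds, whether a hydroxyl, an ethoxy group or a dimethylamino group at this place would also give a high reading remains open. So does whether a carboxylic acid would resemble acetyl in this assay.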